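A few compounds are considered here, and "the series" means these few. Any claim that something is new, unique, unknown or untested is made for them only; others in the source may bear on it.

Measured so far:
compound 1 `CCCCOc1cc(C(C)=O)ccc1NS(C)(=O)=O`: 72.7%
compound 2 `CCCCCCOc1cc(C(C)=O)ccc1N`: 14.1%

Both numbers come from a functional assay on the whole organism (strain Wistar) for inhibition, with Rattus norvegicus as the target, read by paw edema, with stated times of 30 min and 5 h, at a dose of 100 mg/kg by the oral route; a higher number here means more inhibition at the dose given (going by the name of the read-out), a lower number less inhibition. Compound 2 stands lowest of the two; compound 1 lies well above it, a gap beyond the scatter. Within the data shown here, the two differ in more than one place, so no single step between them is counted and the gap is read only as what the two values show. Compound 3 `CCCCCCOc1cc(C(C)=O)ccc1NS(C)(=O)=O` is not yet measured. It keeps everything of compound 2 except the ring nitrogen: methylsulfonyl in place of hydrogen on a nitrogen on an aromatic ring. Among the measured compounds shown here, the only guide to the direction is compound 1, which carries the same methanesulfonamido group and gives 72.7% in this assay. A large upward step is therefore expected, with the remaining uncertainty resting on the other difference between compound 1 and compound 3, for which nothing is measured. The expected step of a number 45.9 percentage points higher from compound 2 to compound 3 (beyond the scatter) is well beyond the scatter. Compound 3 is estimated at 60%, range 35% to 80%.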

Compound 3, a percentage reported as inhibition, in the whole organism at one dose (the size of the read-out at that dose, not a potency): 76.8%
For compound 3 the middle estimate is 16.8 percentage points below the measured one, and the stated range covers the measured number.
By their numbers in this assay, from the lowest: compound 2; then compounds 1 and 3 (each within the scatter of the next).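

In this assay, methylsulfonyl in place of hydrogen on a nitrogen on an aromatic ring can now be read as a single change: a number 62.7 percentage points higher from compound 2 to compound 3 (beyond the scatter), a large step with the rest of compound 2 unchanged. Ethyl in place of hydrogen on a saturated chain carbon, four bonds along the chain from an oxygen on an aromatic ring, gives a number 4.1 percentage points higher from compound 1 to compound 3 (within the scatter), so this chain change does not separate the two compounds in this read-out. Nothing measured here speaks to the reason for either step.

The methylsulfonyl step is read on one chain only, since compound 1 has no partner with a free amino group among the compounds shown. Open too, on these data alone, is how ethylsulfonyl or benzenesulfonyl on the same nitrogen, or a longer chain on the oxygen, would read.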